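The source may report more compounds than this note shows. Statements on the series, on what has been measured and on what is new or still open speak of the compounds shown alone.

Notes on the series in an ADME assay on HepG2 cells (Homo sapiens) for cytotoxicity, read by CellTiter-Glo, with a stated time of 48 h; a lower number here means that less compound is tolerated, a higher number that more compound is tolerated. Compound 1 (`Cc1ccc(-c2nc3cc(Cl)c(Cl)cc3nc2-c2ccccc2)cc1`) reads > 100000 nM, which is a limit of the assay and not a number. Compound 2 (`C[S+]([O-])c1ccc(-c2nc3ccc(Cl)cc3nc2-c2ccc(Cl)cc2)cc1`) gives 1580 nM and compound 3 (`CS(=O)(=O)c1ccc(-c2nc3ccc(Cl)cc3nc2-c2ccc(Cl)cc2)cc1`) gives 2000 nM, so these two stand level within the scatter. The next change leads to compound 4 (`CS(=O)(=O)c1ccc(-c2nc3ccc(Br)cc3nc2-c2ccc(Cl)cc2)cc1`), with bromo in place of chloro on an aromatic carbon of the fused system. Within the data shown here, only one measured step is available, a 1.3-fold higher number from compound 2 to compound 3 (0.10 log units; within the scatter), and it concerns a different group, so it offers only weak guidance. No shift beyond the scatter is expected in this assay, and the estimated step is a 1.1-fold lower number from compound 3 to compound 4 (0.02 log units; within the scatter). Compound 4 is expected at 1900 nM, within an estimated range of 900 nM to 4000 nM.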

Compound 4, half-maximal cytotoxic concentration: 2000 nM
Compound 4: the middle estimate sits 1.1-fold (0.02 log units) below what was measured; low and high end bracket the measured number.
By their numbers in this assay, from the lowest: compounds 2, 3 and 4 (each within the scatter of the next). At a limit, above all of these: compound 1.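

Bromo in place of chloro on this aromatic carbon of the fused system gives in this assay no change at the digits printed from compound 3 to compound 4 (within the scatter). Among these compounds, this is the first reading at this position, as the earlier step concerned the sulfur-bearing group on the other side of the shared core, and here the exchange of one halogen for the other leaves the number level. Nothing available bears on why the read-out holds across this exchange. As far as these compounds go, whether an amine or a carboxylic acid on this carbon would move the number stays open.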